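This account rests on a few compounds, and the source may have more. Where it says the series, first, only, none or still open, it means among the compounds named here.

Compound 1 `N#C/C(=C\c1c[nH]c2ccccc12)C(=O)c1c[nH]c2ccccc12` gives 7600 nM in a functional assay on A-431 cells (Homo sapiens) for inhibition, read by MTT assay, with a stated time of 72 h; on this read-out lower numbers stand for stronger inhibition of growth and higher numbers for weaker inhibition of growth. Compound 2 `COc1ccc(CNC(=O)/C(C#N)=C/c2ccc[nH]2)cc1` yields in this assay only a limit, > 50000 nM. Compound 3 `N#C/C(=C\c1ccc[nH]1)C(=O)NCc1ccc(Cl)c(Cl)c1` likewise yields only a limit, > 50000 nM. Compound 2 therefore stands at the weak end of what the three numbers show, and the limit of > 50000 nM in this assay, at which 2 of the 3 values shown sit, marks where it and one other sit. The change from compound 2 to compound 4 `COc1ccc(CNC(=O)/C(C#N)=C/c2ccc(Cl)o2)cc1` is 5-chlorofuran-2-yl in place of 1H-pyrrol-2-yl on a double-bonded chain carbon bound to a double-bonded chain carbon. For the measured compounds named here, no measured pair shows what this change does, so a step of an at least 1.1-fold lower number from compound 2 to compound 4 (0.04 log units; that floor lies within the scatter) is expected, that is, none clearly beyond the scatter. Compound 4 is expected to give 45000 nM, with a range from 12000 nM to 150000 nM, and most likely again only a limit.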

Compound 4, concentration for 50% growth inhibition: 9000 nM
For compound 4 the middle estimate is 5.0-fold (0.70 log units) above the measured one, outside the stated range (below it).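

In this assay, the position on a double-bonded chain carbon bound to a double-bonded chain carbon proves able to shift growth inhibition: 5-chlorofuran-2-yl in place of 1H-pyrrol-2-yl gives an at least 5.5-fold lower number from compound 2 to compound 4 (0.74 log units; beyond the scatter). This size is only a floor, since the value of compound 2 is a limit: the limit of > 50000 nM in this assay, at which 2 of the 4 values shown sit.

The change swaps the ring and adds chlorine at once, so the compounds shown do not tell these two apart. On these data alone, whether plain furan-2-yl or 5-methylfuran-2-yl would give a similar step remains open, as does whether the step carries over to the amide of compound 3.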